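The source may hold more compounds than are shown below. What is called first, only, known or untested is meant among the compounds shown, and "the series" means these compounds.

Compound 1, with the structure `c1ccc(-c2cccc3c2CCC3c2ncc[nH]2)nc1`, is measured in a functional assay on CHO cells for agonist activity at Alpha-1A adrenergic receptor (Homo sapiens), read by FLIPR and calcium flux (a lower number here means a smaller maximal response, a higher number a larger maximal response), where compound 1 gives 53%. Among the three compounds measured so far this places compound 1 second highest. Compound 2, with the structure `CS(=O)(=O)Nc1cccc2c1CCC2c1ncc[nH]1`, gives 87%, and compound 3, with the structure `c1cncc(-c2cccc3c2CCC3c2ncc[nH]2)c1`, gives 36%. The step from compound 1 to compound 2 is a number 34 percentage points higher from compound 1 to compound 2 (beyond the scatter); the step from compound 1 to compound 3 is a number 17 percentage points lower from compound 1 to compound 3 (beyond the scatter); and the step from compound 2 to compound 3 is a number 51 percentage points lower from compound 2 to compound 3 (beyond the scatter).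

Compound 4, with the structure `c1cc(-c2nccs2)c2c(c1)C(c1ncc[nH]1)CC2`, differs from compound 1 in one place: 1,3-thiazol-2-yl in place of pyridin-2-yl on an aromatic carbon. Among the measured compounds shown here, of the measured steps, the one from compound 1 to compound 3 bears most closely on this change, since it also exchanges one aromatic heterocycle for another at the same position and gave a modest decrease. The large step to compound 2 involves a methanesulfonamido group and is less comparable. The step from compound 1 to compound 4 is therefore expected to be a number 8 percentage points lower from compound 1 to compound 4 (within the scatter), a modest change, most likely downward but with the direction not certain. For compound 4 in this assay the estimated value is 45%, with a range from 25% to 70%.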

Compound 4, largest response reached (Emax), in percent of the reference or control that the assay uses: 64%
Compound 4: middle estimate off by 19 percentage points, on the low side; low and high end bracket the measured number.
By their numbers in this assay, from the lowest: compound 3; then compound 1; then compound 4; then compound 2.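

In this assay, putting 1,3-thiazol-2-yl in place of pyridin-2-yl on this aromatic carbon gives a number 11 percentage points higher from compound 1 to compound 4 (beyond the scatter), so exchanging one aromatic heterocycle for another here can raise the number as well as lower it, which the pyridin-3-yl group alone had not shown. The choice of ring matters at this position, as the exchange of pyridin-3-yl for the five-membered 1,3-thiazol-2-yl gives a number 28 percentage points higher from compound 3 to compound 4 (beyond the scatter), yet the thiazole does not match the methanesulfonamido group, with a number 23 percentage points lower from compound 2 to compound 4 (beyond the scatter), so the methanesulfonamido group keeps the highest number of the four. Nothing available here explains why the ring exchange moves the maximal response in this way.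

The compounds shown carry only aromatic rings and one methanesulfonamido group at this carbon, so it remains open how an amine, a carboxylic acid or a longer alkyl chain would behave there. Going by these compounds, it also remains open whether a furan or an oxazole would follow the 1,3-thiazol-2-yl group, and whether the same order of groups would hold on another aromatic carbon of the shared core.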